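A few compounds are considered here, and "the series" means these few. Any claim that something is new, unique, unknown or untested is made for them only; others in the source may bear on it.

Compound 1 `CCC(=O)OC1C(C(O)CO)OC2OC(C)(C)OC21`: 2400000 nM
Compound 2 `CCCCCC(=O)OC1C(C(O)CO)OC2OC(C)(C)OC21`: 1200000 nM
Compound 3 `CC1(C)OC2OC(C(O)CO)C(OC(=O)C3CCCC3)C2O1`: 2500000 nM

These values come from a functional assay on K562 cells (Homo sapiens) for inhibition (on this read-out lower numbers stand for stronger inhibition and higher numbers for weaker inhibition), and the compounds differ only in the group on a carbonyl carbon. All three numbers are large and lie close together. Compound 3 matches compound 1 within the scatter, while its number lies modestly above that of compound 2.

Compound 4 `CCCCC(=O)OC1C(C(O)CO)OC2OC(C)(C)OC21` trades the ring for an open chain, with butyl in place of cyclopentyl on a carbonyl carbon. The nearest measured guide is compound 2, which carries pentyl, so the step of a 2.1-fold higher number from compound 2 to compound 3 (0.32 log units; beyond the scatter) can be read backwards. Two other steps are also informative. The step of a 1.0-fold higher number from compound 1 to compound 3 (0.02 log units; within the scatter) shows that cyclopentyl and ethyl give matching values, and the step of a 2.0-fold lower number from compound 1 to compound 2 (0.30 log units; within the scatter) stays within the scatter. Open chains therefore seem to offer little room for change.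

A small move to a lower number is expected: a 1.6-fold lower number from compound 3 to compound 4 (0.19 log units; within the scatter). For compound 4 the estimate is 1600000 nM, with an expected range of 900000 nM to 2800000 nM.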

Compound 4, half-maximal inhibitory concentration: 2000000 nM
Estimate against measurement, compound 4: 1.3-fold (0.10 log units) below; low and high end bracket the measured number.
By their numbers in this assay, from the lowest: compounds 2, 4, 1 and 3 (each within the scatter of the next, the first and the last beyond it).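

In this assay, butyl on the carbonyl carbon cannot be told apart from cyclopentyl, with a 1.3-fold lower number from compound 3 to compound 4 (0.10 log units; within the scatter), so at this position an open chain and this ring read alike. Butyl also sits within the scatter of the ethyl and pentyl compounds, as shown by a 1.2-fold lower number from compound 1 to compound 4 (0.08 log units; within the scatter) and a 1.7-fold higher number from compound 2 to compound 4 (0.22 log units; within the scatter), so chain length shows no clear trend across these three compounds. Among these compounds, compound 4 thus stands within the scatter of all three others, and the one step beyond the scatter remains a 2.1-fold higher number from compound 2 to compound 3 (0.32 log units; beyond the scatter), which is modest. No measurement at hand helps explain this flat picture.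

Every group so far is built of carbon only, and all the values are very large. As far as these compounds go, it remains open whether a much longer chain, a phenyl ring or an amine at this position would move the number clearly away from this level.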